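The compounds below may be only part of what the source reports. "The series", "measured", "known", "first", "only" and "open" are said of these compounds alone.

Measured in a functional assay on MGC-803 cells (Homo sapiens) for inhibition, read by sulforhodamine B assay; a lower number here means a stronger inhibitor, a higher number a weaker inhibitor:
- Compound 1 `O=C1C=C(NCc2ccccc2)C(=O)c2c1nc1n2[C@H]2OC[C@@H](O)[C@H]2OC1`: 2670 nM
- Compound 2 `O=C1C=C(Nc2ccccc2F)C(=O)c2c1nc1n2[C@H]2OC[C@@H](O)[C@H]2OC1`: 2080 nM
- Compound 3 `O=C1C=C(NC2CCCC2)C(=O)c2c1nc1n2[C@H]2OC[C@@H](O)[C@H]2OC1`: > 8000 nM (a limit, not a number)

Compound 3 has no exact number, and its entry of > 8000 nM is only a limit of the assay.

Two measured steps end at this compound: an at least 2.9-fold higher number from compound 1 to compound 3 (0.47 log units; beyond the scatter), and an at least 3.8-fold higher number from compound 2 to compound 3 (0.58 log units; beyond the scatter). Both lie beyond the scatter. The remaining step, a 1.3-fold lower number from compound 1 to compound 2 (0.11 log units; within the scatter), lies within it.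

Compound 4 `O=C1C=C(Nc2ccc(Br)cc2)C(=O)c2c1nc1n2[C@H]2OC[C@@H](O)[C@H]2OC1` differs from compound 3 as follows: 4-bromophenyl in place of cyclopentyl on an amine nitrogen. That is, 4-bromophenyl stands in place of cyclopentyl on an amine nitrogen. Compound 2 carries 2-fluorophenyl at the same place, so its step of an at least 3.8-fold higher number from compound 2 to compound 3 (0.58 log units; beyond the scatter), read in reverse, is the closest guide. Going by the values given here, no measured compound here carries a bromine, so that part of the change is untested.

A move to a lower number, beyond the scatter, is therefore expected in this assay. The expected step is an at least 3.2-fold lower number from compound 3 to compound 4 (0.50 log units; beyond the scatter). Compound 4 is estimated at 2500 nM, with an expected range of 1000 nM to 6500 nM.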

Compound 4, half-maximal inhibitory concentration: 1010 nM
Estimate against measurement, compound 4: 2.5-fold (0.39 log units) above; the range from low to high includes it.
By their numbers in this assay, from the lowest: compound 4; then compounds 2 and 1 (each within the scatter of the next). At a limit, above all of these: compound 3.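

In this assay, compound 4 is the strongest inhibitor shown, and the result reveals differences among ring-bearing groups on this amine nitrogen that the near-tie of compound 1 and compound 2 did not show. Putting 4-bromophenyl in place of 2-fluorophenyl gives a 2.1-fold lower number from compound 2 to compound 4 (0.31 log units; beyond the scatter), and putting it in place of benzyl gives a 2.6-fold lower number from compound 1 to compound 4 (0.42 log units; beyond the scatter). Putting it in place of cyclopentyl gives an at least 7.9-fold lower number from compound 3 to compound 4 (0.89 log units; beyond the scatter), but the true size of that step stays unknown because one end of it is a limit: the limit of > 8000 nM in this assay, at which 1 of the 4 values shown sits.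

Compound 2 and compound 4 carry different halogens at different places on the phenyl ring, so the two changes cannot be told apart. As far as these compounds go, how a plain phenyl, a 4-chlorophenyl or a longer alkyl chain would behave on this nitrogen remains open.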